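The compounds below may be only part of what the source reports. "The series", "measured", "known", "first", "only" and "open" are said of these compounds alone.

Working notes on the series. In a functional assay on U-937 cells (Homo sapiens), read by cAMP accumulation (on this read-out higher numbers stand for an effect only at larger amounts of compound and lower numbers for an effect already at smaller amounts), compound 3 (`CCc1nn(C2CCCC2)c2c1CCN(c1cccs1)C2=O`) gives 1 nM, the lowest number of the three measured. Compound 2 (`CCc1nn(C2CCC2)c2c1CCN(c1cccc(OC)c1)C2=O`) gives 520 nM and compound 1 (`CCc1nn(C2CCCCC2)c2c1CCN(c1cccc(OC)c1)C2=O`) gives 980 nM, both higher than compound 3 by margins beyond the scatter.

The next structure is compound 4 (`CCc1nn(C2CCCC2)c2c1CCN(Cc1ccccc1)C2=O`), with benzyl in place of thiophen-2-yl on an amide-type nitrogen in a ring. The change is benzyl in place of thiophen-2-yl on an amide-type nitrogen in a ring.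

Going by the values given here, the only measured step, a 1.9-fold lower number from compound 1 to compound 2 (0.28 log units; within the scatter), lies at another place and stays within the scatter, so it gives no size for this change. Among the compounds with values here, no measured pair isolates the group on the amide-type nitrogen. Compound 2, at 520 nM, carries a different group there but also differs from compound 3 at the aromatic nitrogen, so it is only a loose guide.

Since compound 3 sits at the low end, a higher number is expected in this assay, beyond the scatter but with wide uncertainty. The estimated step is a 150-fold higher number from compound 3 to compound 4 (2.18 log units; beyond the scatter). For compound 4 the expected value is 150 nM, with an estimated range of 10 nM to 2000 nM.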

Compound 4, half-maximal effective concentration: 36 nM
The estimate for compound 4 lay 4.2-fold (0.62 log units) above the measured number, within the range that was stated.
By their numbers in this assay, from the lowest: compound 3; then compound 4; then compounds 2 and 1 (each within the scatter of the next).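

Going by these compounds alone, this is the first pair that isolates the group on the amide-type nitrogen in a ring, with the rest of the structure held constant. In this assay, benzyl in place of thiophen-2-yl gives a 36-fold higher number from compound 3 to compound 4 (1.56 log units; beyond the scatter), so this position clearly affects the read-out, and the size of the step is large. No supporting data explain the step.

Within the data shown here, the single pair does not separate the change of aromatic ring from the added carbon link, since the thiophen-2-yl ring sits directly on the nitrogen and the benzyl ring does not. The compounds shown leave open how a thiophen-2-ylmethyl group, a plain phenyl ring or a longer chain such as phenethyl would behave at this position with the cyclopentyl group retained.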